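Compound 4: an amino group added to compound 3

A few compounds are considered here, and "the series" means these few. Any claim that something is new, unique, unknown or untested is made for them only; others in the source may bear on it.

Measured in a functional assay on NCI-H460 cells (Homo sapiens) for antiproliferative activity, read by XTT assay, with a stated time of 72 h; on this read-out lower numbers stand for stronger inhibition and higher numbers for weaker inhibition:
Compound 1, `COc1ccc(C(=O)/C=C/c2nc3ccccc3cc2-c2ccc(OC)cc2)cc1`, gives only an assay limit, > 10000 nM.
Compound 2, `COc1ccc(-c2cc3ccccc3nc2/C=C/C(=O)c2ccc([N+](=O)[O-])cc2)cc1`, gives 6470 nM.
Compound 3, `COc1ccc(-c2cc3ccccc3nc2/C=C/C(=O)c2cccs2)cc1`, gives 5440 nM.

Of the two numbers shown, compound 3 holds the lower one, but only by a 1.2-fold lower number from compound 2 to compound 3 (0.08 log units; within the scatter), a gap inside the scatter. The value of compound 1 is a limit and nothing more, (the limit of > 10000 nM in this assay, at which 1 of the 3 values shown sits).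

Compound 4, `COc1ccc(-c2cc3ccccc3nc2/C=C/C(=O)c2sccc2N)cc1`, differs from compound 3 by amino in place of hydrogen on an aromatic carbon. Within the data shown here, no measured step touches the same spot. Two steps exchange the whole ring on the carbonyl carbon, an at least 1.8-fold lower number from compound 1 to compound 3 (0.26 log units; that floor lies within the scatter) and a 1.2-fold lower number from compound 2 to compound 3 (0.08 log units; within the scatter), the first of them starting from a limit. One step swaps a substituent on that ring for another, an at least 1.5-fold lower number from compound 1 to compound 2 (0.18 log units; that floor lies within the scatter), and its floor also sits inside the scatter. None of the three steps reaches beyond the scatter, so the addition of the amino group is expected to change little in this assay. The expected step, a 1.1-fold lower number from compound 3 to compound 4 (0.04 log units; within the scatter), is estimated to lie inside the scatter. Compound 4 is therefore estimated at 5000 nM, with a range from 1800 nM to 14000 nM.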

Compound 4, half-maximal inhibitory concentration: > 10000 nM
Compound 4 was reported as a limit (the forecaster's own chance of this, stated with the estimate: 25%); at least 2.0-fold (0.30 log units) between middle value and limit.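

Among these compounds, the amino group sits on an aromatic carbon of the five-membered ring with one sulfur, next to the ring atom that bears a large group, a spot that no earlier step touched, and in this assay adding it gives an at least 1.8-fold higher number from compound 3 to compound 4 (0.26 log units; that floor lies within the scatter). Exchanging the whole ring on the carbonyl carbon for 3-aminothiophen-2-yl gives an at least 1.5-fold higher number from compound 2 to compound 4 (0.18 log units; that floor lies within the scatter), and as with the first step, the floor is all that can be read and it does not clear the scatter, while the step between compound 1 and compound 4 cannot be read at all. Compound 4 therefore gives no number, only a limit, and it is the second compound shown to do so: the limit of > 10000 nM in this assay, at which 2 of the 4 values shown sit.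

Going by these compounds, how large the real loss is, if there is one, stays open, since a limit gives only a floor for both steps. Also open, on these data alone, is whether a hydroxyl group, a methyl group or an acetamide on the same ring carbon would behave as the amino group does, or whether an amine on the 4-nitrophenyl ring would do the same.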